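The source may report more compounds than this note shows. Statements on the series, on what has been measured and on what is new or still open speak of the compounds shown alone.

Measured so far in an ADME assay on MRC5 cells (Homo sapiens), read by MTT assay, with a stated time of 72 h; on this read-out lower numbers stand for stronger inhibition and higher numbers for weaker inhibition:
Compound 1 `C#Cc1cn([C@@H]2O[C@H](CO)[C@@H](O)[C@H]2O)c2ncnc(SC)c12`: > 100000 nM, a limit.
Compound 2 `CNc1ncnc2c1c(-c1ccoc1)cn2[C@@H]1O[C@H](CO)[C@@H](O)[C@H]1O`: > 100000 nM, a limit.
Compound 3 `CNc1ncnc2c1c(-c1ccccc1)cn2[C@@H]1O[C@H](CO)[C@@H](O)[C@H]1O`: > 100000 nM, a limit.

In this assay, compound 3 has no number, only the limit > 100000 nM, and the two other measured compounds also have only limits. The next compound, compound 4 `C#Cc1cn([C@@H]2O[C@H](CO)[C@@H](O)[C@H]2O)c2ncnc(NC)c12`, carries ethynyl in place of phenyl on an aromatic carbon.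

Among the compounds with values here, the only measured step of a similar kind is a step that the two limits leave unreadable from compound 2 to compound 3, where phenyl replaces furan-3-yl on an aromatic carbon. It gives no usable size. The wider picture is the limit of > 100000 nM in this assay, at which 3 of the 3 values shown sit. Within the data shown here, no measured step therefore sets a size or a direction for this change, and no step beyond the scatter is expected in this assay.

The expected step, resting on a step that the two limits leave unreadable from compound 2 to compound 3 alone, is a number no higher from compound 3 to compound 4 (the limit leaves the size open). Compound 4 is estimated at 100000 nM, with an expected range of 20000 nM to 200000 nM, and a report of only a limit is likely.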

Compound 4, half-maximal inhibitory concentration: > 100000 nM
Compound 4: a limit, no number; the forecaster's own chance of this, stated with the estimate: 70%; the middle value lies on the limit itself.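

In this assay compound 4 gives > 100000 nM as a limit and not a number. Its steps from compound 1, compound 2 and compound 3 cannot be read, since every value shown is a limit: the limit of > 100000 nM in this assay, at which 4 of the 4 values shown sit.

The compounds shown leave open how large any of these changes is, and in which direction it runs.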